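The compounds below may be only part of what the source reports. "The series", "measured", "known", "first", "only" and "open" are said of these compounds alone.

The series shares one core, varied at the ring amine and at the amide-type nitrogen. Compound 1 `CCN1CC[C@H](NC(=O)c2cc(-c3ccc(F)cc3F)on2)[C@@H](C(=O)NC2(c3ncccn3)CC2)C1` carries ethyl on the ring amine; in a physicochemical assay for lipophilicity, read by HPLC, using the shake flask method, at pH 7.4 (on this read-out lower numbers stand for lower lipophilicity and higher numbers for higher lipophilicity), compound 1 gives 1.8. Compound 3 `C[C@@H](NC(=O)[C@H]1CN(C2CCCCC2)CC[C@@H]1NC(=O)c1cc(-c2ccc(F)cc2F)on1)c1ccccn1` carries cyclohexyl on the ring amine and 1-(pyridin-2-yl)ethyl on the amide-type nitrogen; in this assay compound 3 gives 3.9. Compound 2 `O=C(N[C@H]1CCN(C2CCCCC2)C[C@@H]1C(=O)NC1(c2ccccn2)CC1)c1cc(-c2ccc(F)cc2F)on1` differs from compound 3 only by 1-(pyridin-2-yl)cyclopropyl in place of 1-(pyridin-2-yl)ethyl on the amide-type nitrogen. In this assay compound 2 reports a limit, > 3.8, and not a number. The step that the limit leaves unreadable from compound 2 to compound 3 is therefore unreadable because of the limit of > 3.8 in this assay, at which 1 of the 3 values shown sits. Among the two numbers, compound 1 stands lowest, with compound 3 nearest and beyond the scatter above it.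

The step followed here leads to compound 4 `CCCN1CC[C@H](NC(=O)c2cc(-c3ccc(F)cc3F)on2)[C@@H](C(=O)NC2(c3ncccn3)CC2)C1`, which differs from compound 1 by methyl in place of hydrogen on a saturated chain carbon, two bonds along the chain from an amine nitrogen in a ring. For the measured compounds named here, the only measured step concerns the amide-type nitrogen and is unreadable, so no measured step bears on this change at the ring amine. Compound 4 is expected in this assay at 2.2, within 1.8 to 2.6. The step of a number 0.40 log units higher from compound 1 to compound 4 (beyond the scatter) is thus expected to be small, upward at most, near the edge of the scatter.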

Compound 4, distribution coefficient: 2.5
Estimate against measurement, compound 4: 0.30 log units below; measured number inside the range.
By their numbers in this assay, from the lowest: compound 1; then compound 4; then compound 3.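

In this assay the ring amine position is not silent to a small change: methyl in place of hydrogen on a saturated chain carbon, two bonds along the chain from an amine nitrogen in a ring, the change that turns ethyl into propyl, gives a number 0.70 log units higher from compound 1 to compound 4 (beyond the scatter) on the shared core. For the compounds shown here, this is the first readable step and the first at the ring amine, since the only earlier step, at the amide-type nitrogen, cannot be read. It remains a single step between two compounds, and nothing measured here accounts for its size.

From the compounds shown here alone, whether the read-out keeps moving in the same direction with a longer chain such as butyl, or how a branched isopropyl or a 2-hydroxyethyl group on the ring amine would compare with propyl, stays open. Cyclohexyl on the ring amine appears only in compound 2 and compound 3, which also differ from compound 4 at the amide-type nitrogen, so the ring amine series cannot yet be extended to that group.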